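A few compounds are considered here, and "the series" means these few. Any claim that something is new, unique, unknown or untested is made for them only; others in the source may bear on it.

Measured so far in an assay on Sf9 cells for inhibition of mitogen-activated protein kinase kinase kinase 14 (Homo sapiens), read by ADP-Glo, with a stated time of 60 min; a lower number here means a stronger inhibitor, a higher number a weaker inhibitor:
Compound 1 `Cc1[nH]nc(N)c1-c1cccc(Br)c1` gives > 100000 nM, which is a limit of the assay and not a number.
Compound 2 `Cc1[nH]nc(N)c1-c1cccc(OC(F)(F)F)c1` gives > 100000 nM, likewise a limit.
Compound 3 `Cc1nn(C(=O)C2CC2)c(N)c1-c1ccc(Cl)c(Cl)c1` gives 24300 nM.

Going by the values given here, compound 3 is thus the only member of the set with a number in this assay; the two others sit at a limit. The step from compound 1 to compound 2 reads a step that the two limits leave unreadable from compound 1 to compound 2; with both ends at the limit of > 100000 nM in this assay, at which 2 of the 3 values shown sit, its size cannot be read, so it teaches nothing about size or direction.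

Compound 4 `Cc1nn(C(=O)c2cccnc2)c(N)c1-c1ccc(Cl)c(Cl)c1` differs from compound 3 in one place: pyridin-3-yl in place of cyclopropyl on a carbonyl carbon. Among the compounds with values here, no measured step touches the group on the carbonyl carbon. Within the data shown here, the one measured step, from compound 1 to compound 2, concerns a substituent on an aromatic carbon and is unreadable in any case. There is therefore no measured basis for a direction, and the step in this assay from compound 3 to compound 4 is expected to be a 1.2-fold lower number from compound 3 to compound 4 (0.08 log units; within the scatter), i.e. nothing beyond the scatter. Compound 4 is accordingly expected to give about 20000 nM in this assay, with a range from 5000 nM to 100000 nM, and with a fair chance that the assay reports only a limit rather than a number.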

Compound 4, half-maximal inhibitory concentration: > 100000 nM
Compound 4: only a limit was reported; the forecaster's own chance of this, stated with the estimate: 25%; middle value at least 5.0-fold (0.69 log units) away from the limit.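

In this assay, going by these compounds alone, the group on the carbonyl carbon is the first place where a change can be read, and pyridin-3-yl in place of cyclopropyl there gives an at least 4.1-fold higher number from compound 3 to compound 4 (0.61 log units; beyond the scatter). Compound 4 gives > 100000 nM, which is a limit of the assay and not a number. The change therefore has a readable direction, with the six-membered aromatic ring and its hydrogen-bond acceptor on the weaker side of the pair, but its full size stays unread, and the series still rests on a single number: the limit of > 100000 nM in this assay, at which 3 of the 4 values shown sit.

The compounds shown leave open whether an alkyl group such as methyl or tert-butyl, a plain phenyl ring, or an amine such as piperidin-4-yl on the carbonyl carbon would give a number in this assay, and a plain phenyl ring would also separate the ring nitrogen from the ring itself. No single-place pair shown separates the effect of the acyl group from that of the substituents on the aromatic ring, so how those two parts of the compounds combine remains unknown.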